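A few compounds are considered here, and "the series" means these few. Any claim that something is new, unique, unknown or untested is made for them only; others in the source may bear on it.

In a functional assay on a cell-free system (Platelet, plasma, Homo sapiens) for inhibition, read by turbidimetry, with a stated time of 3 min (on this read-out higher numbers stand for weaker inhibition and lower numbers for stronger inhibition), two compounds with a shared core have been measured. Compound 1 (`COc1ccc(-n2nc(C(=O)N3CCOCC3)cc2-c2ccc(Cl)cc2)nn1`) gives 83 nM and compound 2 (`COc1ccc(-n2nc(CCC(=O)N3CCCCC3)cc2-c2ccc(Cl)cc2)nn1`) gives 920 nM, the higher of the two numbers and so the weaker inhibition.

Compound 3 (`COc1ccc(-n2nc(CCC(=O)N3CCOCC3)cc2-c2ccc(Cl)cc2)nn1`) keeps the chain of compound 2 and alters only the ring of its amide (morpholin-4-yl in place of piperidin-1-yl on a carbonyl carbon), with morpholin-4-yl in place of piperidin-1-yl on a carbonyl carbon. Within the data shown here, one measured step bears on this (an 11-fold higher number from compound 1 to compound 2 (1.04 log units; beyond the scatter)). Among the measured compounds shown here, that step is large, but chain and ring change together in it, and no measured pair shows the ring swap alone.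

Compound 3 pairs the chain of compound 2 (920 nM) with the ring of compound 1 (83 nM). It is therefore expected to cover only part of that gap, so a moderate move toward a lower number is expected in this assay rather than the full distance. The expected step is an estimate with wide uncertainty (a 2.3-fold lower number from compound 2 to compound 3 (0.36 log units; beyond the scatter)). For compound 3 the estimated value is 400 nM (expected range 130 nM to 1200 nM).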

Compound 3, half-maximal inhibitory concentration: 1080 nM
Estimate against measurement, compound 3: 2.7-fold (0.43 log units) below; the range from low to high includes it.
By their numbers in this assay, from the lowest: compound 1; then compounds 2 and 3 (each within the scatter of the next).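

In this assay, morpholin-4-yl in place of piperidin-1-yl on a carbonyl carbon gives a 1.2-fold higher number from compound 2 to compound 3 (0.07 log units; within the scatter), so on this chain the ring of the amide makes no readable difference, even though morpholin-4-yl brings a second hetero atom and a hydrogen-bond acceptor. The large step seen earlier mixed two changes, but with the morpholin-4-yl ring now held constant, the change of (morpholin-4-yl)carbonyl to 2-((morpholin-4-yl)carbonyl)ethyl on the aromatic carbon alone gives a 13-fold higher number from compound 1 to compound 3 (1.11 log units; beyond the scatter) and so accounts for that earlier step on its own. Nothing available explains why this longer attachment weakens inhibition or why the ring swap leaves the number within the scatter.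

Still open, from the compounds shown here alone, is whether the ring matters when the carbonyl sits directly on the aromatic carbon, as (piperidin-1-yl)carbonyl at that place would show, and whether ((morpholin-4-yl)carbonyl)methyl, with its shorter chain, would fall in between. Also open, going by these compounds, is what a carboxylic acid or a simple amine in place of the amide would give in this assay on the shared core.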